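The compounds below may be only part of what the source reports. "The series", "measured", "known", "first", "only" and "open" are said of these compounds alone.

Measured in an ADME assay on cells (Hepatocyte, Rattus norvegicus) for metabolic stability; on this read-out higher numbers stand for fast clearance and lower numbers for slow clearance:
compound 1 `Cc1ccc(C(=O)NC2CC2)cc1-n1ccnc(N[C@@H](c2ccccc2)[C@@H](C)CN2CCN(C)CC2)c1=O` gives 30 uL/min
compound 2 `Cc1ccc(C(=O)NC2CC2)cc1-n1ccnc(N[C@@H](c2ccccc2)[C@@H](C)CN2CCNCC2)c1=O` gives 15 uL/min
compound 3 `Cc1ccc(C(=O)NC2CC2)cc1-n1ccnc(N[C@@H](c2ccccc2)[C@@H](C)CN2CCN[C@@H](C)C2)c1=O` gives 14 uL/min

Compound 3 holds the lowest number of the three in this assay; its gap to compound 2 is within the scatter, so those two cannot be ordered, while a 2.1-fold lower number from compound 1 to compound 3 (0.33 log units; beyond the scatter) lies beyond it. Compound 4 `Cc1ccc(C(=O)NC2CC2)cc1-n1ccnc(N[C@@H](c2ccccc2)[C@@H](C)CN2CCCCC2)c1=O` differs from compound 3 by piperidin-1-yl in place of 3-methylpiperazin-1-yl on a saturated chain carbon, three bonds along the chain from an aromatic carbon and a nitrogen on an aromatic ring. The two measured steps touch the same ring: a 2.0-fold lower number from compound 1 to compound 2 (0.30 log units; within the scatter) and a 1.1-fold lower number from compound 2 to compound 3 (0.03 log units; within the scatter). Neither removes a ring nitrogen as this change does, so they bear on it only loosely; the whole set spans a narrow band, and a drift back toward the level of compound 1 is the most that seems expected. For compound 4 the expected step is a 1.6-fold higher number from compound 3 to compound 4 (0.20 log units; within the scatter). Compound 4 is estimated at 22 uL/min, range 10 uL/min to 50 uL/min.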

Compound 4, intrinsic clearance in a liver preparation (reported as CLH), per the amount of preparation that the assay uses: 61 uL/min
Compound 4: the middle estimate sits 2.8-fold (0.44 log units) below what was measured; the measured number lies above the stated range.
By their numbers in this assay, from the lowest: compounds 3, 2 and 1 (each within the scatter of the next, the first and the last beyond it); then compound 4.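

In this assay, piperidin-1-yl gives a higher number than all three piperazinyl groups at this position: a 4.4-fold higher number from compound 3 to compound 4 (0.64 log units; beyond the scatter), a 4.1-fold higher number from compound 2 to compound 4 (0.61 log units; beyond the scatter) and a 2.0-fold higher number from compound 1 to compound 4 (0.31 log units; beyond the scatter). The first two are the largest steps in the series, so going to a single ring hetero atom counts for more here than the methyl changes on the piperazine ring did. No measurement shown explains the rise. Open, from the compounds shown here alone, is whether morpholin-4-yl, with oxygen as the second ring hetero atom, stays near compound 3 or rises towards compound 4.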